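Series notes: aryl amide swap at the anilide carbonyl

This account rests on a few compounds, and the source may have more. Where it says the series, first, only, none or still open, it means among the compounds named here.

Three compounds of the shared core have numbers in an assay on isolated protein for inhibition of Rho-associated protein kinase 2 (Homo sapiens), read by scintillation counting, radiometric assay and 33P incorporation, with a stated time of 40 min, in the presence of a further agent that is not named here; on this read-out higher numbers stand for weaker inhibition and lower numbers for stronger inhibition. Compound 1 `CC(=O)c1ccc(OCC(=O)Nc2cccc(NC(=O)c3ccc(N(C)C)cc3)c2)cc1F` gives 98 nM. Compound 2 `CN(C)c1ccc(C(=O)Nc2cccc(NC(=O)COc3ccc4c(c3)OCCC4=O)c2)cc1` gives 85 nM. Among the measured compounds shown here, compound 3 `CC(C)(C)c1ccc(C(=O)Nc2cccc(NC(=O)COc3ccc4c(=O)ccoc4c3)c2)cc1` gives 34 nM, the lowest of the three; its gaps to compound 2 and to compound 1 both lie beyond the scatter, so compound 3 is the strongest inhibitor on the numbers so far.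

For the measured compounds named here, the one measured single-point step, a 1.2-fold lower number from compound 1 to compound 2 (0.06 log units; within the scatter), changes the aryloxy part on the oxygen on a saturated carbon and leaves the amide end untouched.

Compound 4 `O=C(COc1ccc2c(=O)ccoc2c1)Nc1cccc(NC(=O)c2cnc(C(F)(F)F)s2)c1` differs from compound 3 at the other end: 2-(trifluoromethyl)-1,3-thiazol-5-yl in place of 4-(tert-butyl)phenyl on a carbonyl carbon. No measured step changes this carbonyl carbon, so nothing shown bears directly on the change; compound 1 and compound 3 differ here as well, but they also differ in the aryloxy part, and their two values alone do not separate the two changes. The expectation for compound 4 is therefore anchored on compound 3 with a wide range: a step of a 1.8-fold higher number from compound 3 to compound 4 (0.25 log units; within the scatter) is estimated, that is, no direction beyond the scatter is predicted. The estimate for compound 4 in this assay is 60 nM, with a range of 15 nM to 250 nM.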

Compound 4, half-maximal inhibitory concentration: 10 nM
For compound 4 the middle estimate is 6.0-fold (0.78 log units) above the measured one, and the stated range ends above it.
By their numbers in this assay, from the lowest: compound 4; then compound 3; then compounds 2 and 1 (each within the scatter of the next).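

In this assay the swap on the carbonyl carbon whose other neighbour is the amide-type nitrogen gives a 3.4-fold lower number from compound 3 to compound 4 (0.53 log units; beyond the scatter) and so lies beyond the scatter, which shows that this end of the molecule, untouched by any earlier single-place step, can shift the number. With the aryloxy part held constant, the 4-(tert-butyl)phenyl group is not required for a low number at this place: compound 4 , carrying the 2-(trifluoromethyl)-1,3-thiazol-5-yl group with its five-membered aromatic ring, gives 10 nM and stands lowest of the four compounds. No measurement at hand gives a reason for this step.

The swap changes the ring and its substituent together, so the compounds shown cannot say whether the step follows the ring, the trifluoromethyl group or their combination; a 4-(trifluoromethyl)phenyl group or an unsubstituted 1,3-thiazol-5-yl group on the same carbonyl carbon would separate the two. As far as these compounds go, it also remains open whether the step carries over to the aryloxy parts of compound 1 and compound 2, and how an amine or a carboxylic acid on the thiazole ring would read in this assay.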